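The source may report more compounds than this note shows. Statements on the series, on what has been measured and on what is new or still open speak of the compounds shown alone.

Measured so far in a functional assay on CHO cells for agonist activity at sphingosine 1-phosphate receptor 5 (Homo sapiens), read by GTPgammaS binding; on this read-out higher numbers stand for an effect only at larger amounts of compound and lower numbers for an effect already at smaller amounts:

compound 1, `Cc1cc(CCC(=O)O)ccc1-c1noc(-c2ccc(OC(C)C)c(C(F)(F)F)c2)n1`, 40 nM
compound 2, `CCOc1ccc(-c2nc(-c3ccc(CCC(=O)O)cc3C)no2)cc1C(F)(F)F`, 260 nM
compound 3, `Cc1cc(CCC(=O)O)ccc1-c1noc(-c2ccc(OC(C)C)c(C#N)c2)n1`, 6.5 nM

The shared core carries two variable groups on one aromatic ring. The step of a 6.5-fold lower number from compound 2 to compound 1 (0.81 log units; beyond the scatter) goes with the change (methyl in place of hydrogen on a saturated chain carbon bound to an oxygen on an aromatic ring and a saturated chain carbon). The step of a 6.2-fold lower number from compound 1 to compound 3 (0.79 log units; beyond the scatter) goes with cyano in place of trifluoromethyl on an aromatic carbon. Compound 3 stands lowest of the three, with both steps to the others beyond the scatter. Between compound 2 and compound 3 the difference between the two cores is not broken down here; their two values show a wide gap.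

Compound 4, `CC[C@H](C)Oc1ccc(-c2nc(-c3ccc(CCC(=O)O)cc3C)no2)cc1C#N`, is not yet measured. It differs from compound 3 by methyl in place of hydrogen on a saturated chain carbon, two bonds along the chain from an oxygen on an aromatic ring. Within the data shown here, this is the same kind of change as the one from compound 2 to compound 1, not the same: there the place was on a saturated chain carbon bound to an oxygen on an aromatic ring and a saturated chain carbon, here it is on a saturated chain carbon, two bonds along the chain from an oxygen on an aromatic ring. The earlier methyl gave a modest step, a 6.5-fold lower number from compound 2 to compound 1 (0.81 log units; beyond the scatter); for a second methyl one bond further out a smaller step is expected, a 1.6-fold lower number from compound 3 to compound 4 (0.21 log units; within the scatter). Compound 4 is therefore estimated at 4 nM, expected between 1.5 nM and 12 nM.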

Compound 4, half-maximal effective concentration: 15 nM
Compound 4: the middle estimate sits 3.8-fold (0.57 log units) below what was measured, and the stated range ends below it.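

In this assay the added methyl on the nitrile core gives a 2.3-fold higher number from compound 3 to compound 4 (0.36 log units; beyond the scatter), so the drop in number seen on the trifluoromethyl core does not carry over to this core. Set side by side, the two steps run in opposite directions and the gap is larger than repeated measurements would explain: the same change on two cores in this assay, a 6.5-fold lower number (0.81 log units; beyond the scatter) from compound 2 to compound 1 and a 2.3-fold higher number (0.36 log units; beyond the scatter) from compound 3 to compound 4, 15-fold (1.18 log units) apart, beyond the scatter of two such steps

This does not show what separates the two steps: the methyl sits at a different place on the chain in each pair, the two pairs also differ in nitrile against trifluoromethyl on the ring, and each step rests on a single pair.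

The compounds shown leave open how ethoxy behaves with the nitrile and how sec-butoxy behaves with trifluoromethyl, two pairings that would put both chain changes on a single core. Also open, from the compounds shown here alone, are the mirror-image sec-butoxy form and longer or cyclic ethers, such as pentyloxy or cyclopentyloxy.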